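The compounds below may be only part of what the source reports. "The series", "measured", "known", "first", "only" and "open" are said of these compounds alone.

Measured compounds:
compound 1 `Cc1nc(NC(C)(C)C)nc(N[C@@H]2C[C@H](CO)[C@@H](O)[C@H]2O)c1-c1nc2ccccc2s1`: 12000 nM
compound 2 `Cc1nc(N(C)C)nc(N[C@@H]2C[C@H](CO)[C@@H](O)[C@H]2O)c1-c1nc2ccccc2s1`: 18000 nM

In an ADME assay on cells (Homo sapiens) for cytotoxicity, read by polymerase chain reaction, with a stated time of 3 days (a lower number here means that less compound is tolerated, a higher number that more compound is tolerated), compound 2 gives the higher of the two numbers, but the step of a 1.5-fold higher number from compound 1 to compound 2 (0.18 log units; within the scatter) is within the scatter, so the two compounds cannot be told apart. Compound 3 `Cc1nc(NCCOC(C)C)nc(N[C@@H]2C[C@H](CO)[C@@H](O)[C@H]2O)c1-c1nc2ccccc2s1` carries (2-isopropoxyethyl)amino in place of dimethylamino on an aromatic carbon. Within the data shown here, the only measured step, a 1.5-fold higher number from compound 1 to compound 2 (0.18 log units; within the scatter), also exchanged the amino group on that aromatic carbon and changed nothing beyond the scatter, so no step beyond the scatter is expected here either, a 1.2-fold lower number from compound 2 to compound 3 (0.08 log units; within the scatter). Compound 3 is therefore estimated at 15000 nM, with a range of 7000 nM to 32000 nM.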

Compound 3, half-maximal cytotoxic concentration: 8000 nM
The estimate for compound 3 lay 1.9-fold (0.27 log units) above the measured number; low and high end bracket the measured number.
By their numbers in this assay, from the lowest: compounds 3, 1 and 2 (each within the scatter of the next, the first and the last beyond it).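

On this aromatic carbon between two ring nitrogen atoms, exchanging the amino group now gives a step beyond the scatter in this assay (a 2.3-fold lower number from compound 2 to compound 3 (0.35 log units; beyond the scatter)), though a modest one. The same (2-isopropoxyethyl)amino group cannot be told apart from the (tert-butyl)amino group (a 1.5-fold lower number from compound 1 to compound 3 (0.18 log units; within the scatter)), so the effect of this change depends on which compound it is compared with. Nothing measured here gives a reason for the step. As far as these compounds go, it remains open how a ring amine such as morpholine would read here, or a chain ending in a carboxylic acid.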